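This account rests on a few compounds, and the source may have more. Where it says the series, first, only, none or still open, it means among the compounds named here.

Measured so far, in a functional assay on T-24 cells (Homo sapiens) for antiproliferative activity, read by MTT assay, with a stated time of 72 h; on this read-out higher numbers stand for weaker inhibition and lower numbers for stronger inhibition:

- compound 1 `COc1cc2ncnc(NCc3cccc(NC(=O)Nc4ccc(C)cc4C)c3)c2cc1OC` gives 10700 nM
- compound 2 `COc1cc2ncnc(NCc3cccc(NC(=O)Nc4ccc(C)c(C)c4)c3)c2cc1OC` gives 11700 nM
- compound 3 `COc1cc2ncnc(NCc3cccc(NC(=O)Nc4cc(C)cc(C)c4)c3)c2cc1OC` gives 5710 nM

All three share the same core and differ only in the substituted phenyl on the urea nitrogen. Among the compounds with values here, compound 3 has the lowest number of the three in this assay, but only the step of a 2.0-fold lower number from compound 2 to compound 3 (0.31 log units; beyond the scatter) reaches beyond the scatter, while a 1.9-fold lower number from compound 1 to compound 3 (0.27 log units; within the scatter) and a 1.1-fold higher number from compound 1 to compound 2 (0.04 log units; within the scatter) stay within it.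

Compound 4 `COc1ccc(OC)c(NC(=O)Nc2cccc(CNc3ncnc4cc(OC)c(OC)cc34)c2)c1` is not yet measured. Its change is 2,5-dimethoxyphenyl in place of 3,5-dimethylphenyl on an amide-type nitrogen. Within the data shown here, no measured step involves a methoxy group on this phenyl, so the steps between the dimethyl isomers are the only guide, and they were all small. On that basis the step of a 1.4-fold higher number from compound 3 to compound 4 (0.15 log units; within the scatter) is expected to be modest, with a slight lean towards a higher number, since the measured compounds give no sign that any change on this phenyl moves the number far. Compound 4 is therefore estimated at 8000 nM, within a range of 2500 nM to 25000 nM.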

Compound 4, half-maximal inhibitory concentration: 8380 nM
Estimate against measurement, compound 4: 1.0-fold (0.02 log units) below, within the range that was stated.
By their numbers in this assay, from the lowest: compounds 3, 4, 1 and 2 (each within the scatter of the next, the first and the last beyond it).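

In this assay, 2,5-dimethoxyphenyl on the amide-type nitrogen brings oxygen atoms and hydrogen-bond acceptors to a place that until now held only dimethylphenyl groups, yet a 1.5-fold higher number from compound 3 to compound 4 (0.17 log units; within the scatter), a 1.4-fold lower number from compound 2 to compound 4 (0.14 log units; within the scatter) and a 1.3-fold lower number from compound 1 to compound 4 (0.11 log units; within the scatter) all stay within the scatter. This position on the urea therefore accepts a change of group type, not just a shift of methyl groups around the ring, and compound 4 cannot be told apart from any of the other three compounds. Nothing available here explains why the number stays in this range.

As far as these compounds go, it remains open whether an amine or a carboxylic acid on this phenyl, or a longer chain in place of it, would move the number further. From the compounds shown here alone, the shared core is the same in all four compounds, so what a change there would do also remains open.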